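This account rests on a few compounds, and the source may have more. Where it says the series, first, only, none or still open, it means among the compounds named here.

Compounds measured in an assay on isolated protein for inhibition of STE20-like serine/threonine-protein kinase (Homo sapiens), read by thermal shift assay, tested at 10 uM; a higher number here means that the compound stabilises the target more against heat, a lower number that the compound stabilises the target less:
- compound 1, `CC(C)(C)c1cc(NC(=O)Nc2cc(C(F)(F)F)cc(C(F)(F)F)c2)n(-c2ccc(F)cc2)n1`: 0.5 degrees C
- compound 2, `CC(C)(C)c1cc(NC(=O)Nc2ccc(Cl)cc2)n(-c2ccc(C#N)cc2)n1`: 1.6 degrees C
- compound 3, `N#Cc1ccc(-n2nc(C3CC3)cc2NC(=O)Nc2ccc(Cl)cc2)cc1`: 0.7 degrees C

Among the compounds with values here, compound 2 and compound 3 give numbers that lie within the scatter of each other, so nothing separates them; compound 1 gives a lower number than compound 2, and that gap is beyond the scatter, though the two differ in more than one place and no single step is drawn between them. Within the data shown here, the one step that is drawn, a number 0.90 degrees C lower from compound 2 to compound 3 (within the scatter), concerns the tert-butyl on the shared core and not the group on the phenyl attached to the core.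

Compound 4, `CC(C)(C)c1cc(NC(=O)Nc2ccc(Cl)cc2)n(-c2ccc(NS(C)(=O)=O)cc2)n1`, is still to be measured in this assay. It differs from compound 2 in this way: methanesulfonamido in place of cyano on an aromatic carbon. Among the measured compounds shown here, no measured step touches the cyano position, so there is nothing in the data to support a shift in either direction. The expectation is therefore a step of about a number 0.30 degrees C lower from compound 2 to compound 4 (within the scatter), that is, none beyond the scatter. Compound 4 is estimated at 1.3 degrees C, expected to fall between 0 degrees C and 2.8 degrees C.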

Compound 4, shift of the target's melting temperature: 7.3 degrees C
Compound 4: the middle estimate sits 6.0 degrees C below what was measured; measured number outside the range, above it.
By their numbers in this assay, from the lowest: compounds 1, 3 and 2 (each within the scatter of the next, the first and the last beyond it); then compound 4.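

In this assay the aromatic carbon para to a large group, which no earlier step touched, turns out to respond strongly: methanesulfonamido in place of cyano gives a number 5.7 degrees C higher from compound 2 to compound 4 (beyond the scatter) and this is the only step shown that lies beyond the scatter. The other step, a number 0.90 degrees C lower from compound 2 to compound 3 (within the scatter) at the tert-butyl, stays within the scatter, so among the two steps shown only the change at this aromatic carbon moves the number. Nothing available bears on why the number rises here, and this single pair cannot separate the entering hydrogen-bond donor from the other differences between the two groups.

The compounds shown leave open how an amine, a carboxylic acid or a longer chain on the sulfonyl would read on this carbon. They also leave open whether the rise from methanesulfonamido persists with cyclopropyl in place of tert-butyl.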